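A few compounds are considered here, and "the series" means these few. Any claim that something is new, unique, unknown or untested is made for them only; others in the source may bear on it.

In a functional assay on the whole organism (strain Wistar) for inhibition, with Rattus norvegicus as the target, read by paw edema, with stated times of 30 min and 3 h, at a dose of 100 mg/kg by the oral route (on this read-out lower numbers stand for less inhibition and higher numbers for more inhibition at the one dose given (going by the name of the read-out)), compound 3 `CCCCOc1cc(C(=O)NCCC)nn1-c1ccccc1` gives 51.2%, the highest of the three numbers measured. Compound 1 `CCCCOc1cc(C(N)=O)nn1-c1ccccc1` gives 26.5%, and compound 2 `C=CCNC(=O)c1cc(OCCCC)n(-c2ccccc2)n1` gives 4.4%. All measured steps concern what sits on the amide-type nitrogen: a number 24.7 percentage points higher from compound 1 to compound 3 (beyond the scatter); a number 22.1 percentage points lower from compound 1 to compound 2 (beyond the scatter); a number 46.8 percentage points higher from compound 2 to compound 3 (beyond the scatter). Compound 4 `CCCCOc1cc(C(=O)N2CCCC2)nn1-c1ccccc1` differs from compound 3 as follows: pyrrolidin-1-yl in place of propylamino on a carbonyl carbon. Within the data shown here, no measured step replaces the amide hydrogen and the chain together by a ring, so the three steps bear on this change only loosely; they show that alterations at the amide-type nitrogen move the read-out modestly to largely in either direction. Compound 4 is therefore expected to show a number 13.2 percentage points lower from compound 3 to compound 4 (beyond the scatter). Compound 4 is estimated at 38%, with a range from 12% to 64%.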

Compound 4, a percentage reported as inhibition, in the whole organism at one dose (the size of the read-out at that dose, not a potency): 17.6%
Compound 4: the middle estimate sits 20.4 percentage points above what was measured; the range from low to high includes it.
By their numbers in this assay, from the lowest: compound 2; then compounds 4 and 1 (each within the scatter of the next); then compound 3.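

In this assay, replacing propylamino with the pyrrolidin-1-yl ring, which carries no hydrogen-bond donor, gives a number 33.6 percentage points lower from compound 3 to compound 4 (beyond the scatter) and so shows that the gain seen with the propyl chain does not carry over to this ring. The ring still stands apart from allylamino, with a number 13.2 percentage points higher from compound 2 to compound 4 (beyond the scatter) and yet against the plain amino group it gives a number 8.9 percentage points lower from compound 1 to compound 4 (within the scatter) and cannot be told apart from it. Nothing available explains these differences. Open, from the compounds shown here alone, is how a piperidine ring or a morpholine ring would compare on this carbonyl carbon. Also open, going by these compounds, is whether a butylamino chain would go beyond propylamino.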